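The source may report more compounds than this note shows. Statements on the series, on what has been measured and on what is new or still open speak of the compounds shown alone.

Measured compounds:
compound 1, `Cc1ccc(C2C(C#N)=C(N)N(c3ccc(S(N)(=O)=O)cc3)C3=C2CCCC3)cc1`, 90%
compound 2, `N#CC1=C(N)N(c2ccc(S(N)(=O)=O)cc2)C2=C(CCCC2)C1c1ccc(O)cc1`, 100%

Both compounds were examined in a functional assay on Ehrlich cells (Mus musculus) for cytotoxicity, read by trypan blue exclusion, with a stated time of 2 h, tested at 100 ug/mL; a lower number here means a weaker effect, a higher number a stronger effect of the compound at the concentration tested. Compound 1 gives 90% and compound 2 gives 100%. Among the compounds with values here, the only step between them, hydroxy in place of methyl on an aromatic carbon, amounts to a number 10 percentage points higher from compound 1 to compound 2 (within the scatter), so the two numbers cannot be told apart, and compound 2 merely sits at the upper end of the two values shown, with compound 1 as its only neighbour.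

The unmeasured compound 3, `N#CC1=C(N)N(c2ccc(S(N)(=O)=O)cc2)C2=C(CCCC2)C1c1cccc([N+](=O)[O-])c1`, differs from compound 2 by 3-nitrophenyl in place of 4-hydroxyphenyl on a saturated ring carbon. Within the data shown here, no measured step involves a 3-nitrophenyl group, so the only guidance is that the one change seen so far on the same saturated ring carbon, from compound 1 to compound 2, stayed within the scatter. Since compound 2 already reports the full read-out 100%, a step beyond the scatter in this assay is expected only downward, if at all, and none is predicted. Compound 3 is therefore estimated at 90%, within 70% to 100%, which corresponds to an expected step of a number 10 percentage points lower from compound 2 to compound 3 (within the scatter).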

Compound 3, a percentage reported as activity, at one concentration (the size of the read-out at that concentration, not a potency): 12%
Compound 3: the middle estimate sits 78 percentage points above what was measured, and the stated range ends above it.
By their numbers in this assay, from the lowest: compound 3; then compounds 1 and 2 (each within the scatter of the next).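

In this assay, the group on the saturated ring carbon proves not to be interchangeable: the change to 3-nitrophenyl brings a number 88 percentage points lower from compound 2 to compound 3 (beyond the scatter), and starting from 4-methylphenyl it brings a number 78 percentage points lower from compound 1 to compound 3 (beyond the scatter), whereas the earlier exchange of methyl for hydroxy on the aromatic ring gave only a number 10 percentage points higher from compound 1 to compound 2 (within the scatter). The loss therefore appears from both starting points, so this position can carry a large change in the read-out, something the first pair gave no sign of. Nothing available here bears on why the read-out falls with this change.

The 3-nitrophenyl group differs from the other two in both the nature of its substituent and that substituent's place on the aromatic ring, so the three compounds cannot say which of the two matters, a question that a 4-nitrophenyl or a 3-hydroxyphenyl group at the same carbon could separate. As far as these compounds go, it also remains open how a plain phenyl or a 3-aminophenyl group would behave there, and whether the same exchange would have a similar effect with anything other than the 4-sulfamoylphenyl group on the ring nitrogen.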